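Replacing the dichlorothiophene on the sulfonyl sulfur

The source may report more compounds than this note shows. Statements on the series, on what has been measured and on what is new or still open speak of the compounds shown alone.

Three compounds have been measured in an assay on isolated protein for displacement of a labelled ligand from prostaglandin E2 receptor EP3 subtype (Homo sapiens), read by scintillation counting, with a stated time of 2 h; on this read-out higher numbers stand for weaker inhibition and lower numbers for stronger inhibition:

Compound 1, `O=C(NC/C=C1\CCCc2cnn(Cc3ccc(Cl)cc3Cl)c21)NS(=O)(=O)c1ccc(Cl)cc1`: 4 nM
Compound 2, `Cn1cc(S(=O)(=O)NC(=O)NC/C=C2\CCCc3cnn(Cc4ccc(Cl)cc4Cl)c32)cn1`: 9 nM
Compound 3, `O=C(NC/C=C1\CCCc2cnn(Cc3ccc(Cl)cc3Cl)c21)NS(=O)(=O)c1cc(Cl)c(Cl)s1`: 0.5 nM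

Compound 3 has the lowest number of the three, and both steps toward it lie beyond the scatter: an 8.0-fold lower number from compound 1 to compound 3 (0.90 log units; beyond the scatter) and an 18-fold lower number from compound 2 to compound 3 (1.26 log units; beyond the scatter). The other pair, a 2.3-fold higher number from compound 1 to compound 2 (0.35 log units; beyond the scatter), is a smaller move. In this set, then, the group on the sulfonyl sulfur matters, and the 4,5-dichlorothiophen-2-yl group gives the strongest binding seen.

Compound 4, `COc1ccccc1S(=O)(=O)NC(=O)NC/C=C1\CCCc2cnn(Cc3ccc(Cl)cc3Cl)c21`, removes that group: 2-methoxyphenyl in place of 4,5-dichlorothiophen-2-yl on a sulfonyl sulfur. Going by the values given here, no step with a 2-methoxyphenyl group has been measured, so the nearest guides are the two steps that brought the 4,5-dichlorothiophen-2-yl group in. Both went down substantially when it entered, so taking it out is expected to send the number up again, most likely by an amount between those two steps, landing compound 4 near compound 1 and compound 2 rather than near compound 3. The step of a 20-fold higher number from compound 3 to compound 4 (1.30 log units; beyond the scatter) is therefore expected to be a clear rise beyond the scatter.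

Compound 4 is estimated at 10 nM, with a range from 3 nM to 40 nM.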

Compound 4, inhibition constant: 62 nM
For compound 4 the middle estimate is 6.2-fold (0.79 log units) below the measured one; the whole stated range lies below it.
By their numbers in this assay, from the lowest: compound 3; then compound 1; then compound 2; then compound 4.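

In this assay the group on the sulfonyl sulfur now covers a much wider range than the first three compounds showed, with a 120-fold higher number from compound 3 to compound 4 (2.09 log units; beyond the scatter) as the largest step of the set and compound 4 as the weakest binder of the four. Taking out the 4,5-dichlorothiophen-2-yl group does not simply return the number to the level of the other two compounds, since the 2-methoxyphenyl group also loses ground against both, with a 6.9-fold higher number from compound 2 to compound 4 (0.84 log units; beyond the scatter) and with a 16-fold higher number from compound 1 to compound 4 (1.19 log units; beyond the scatter) as well. Compound 1 and compound 4 both carry a six-membered aromatic ring of carbon only, so having that ring does not by itself settle the binding, and what the ring carries matters in this pair.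

Going by these compounds, how an unsubstituted phenyl group, or a phenyl ring carrying an amine, would read on this sulfur stays open, so the effect of the methoxy group cannot yet be separated from that of the ring bearing it. No measured evidence bears on this result, and what lies behind the rise remains unexplained.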